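The source may report more compounds than this note shows. Statements on the series, on what has been measured and on what is new or still open speak of the compounds shown alone.

Measured in an ADME assay on HEK293 cells (Homo sapiens) for cytotoxicity, read by CCK-8 assay, with a stated time of 48 h; on this read-out higher numbers stand for weaker inhibition and lower numbers for stronger inhibition:
- compound 1 `COc1ccc(/C=C\c2cc(OC)c(OC)c(OC)c2)cc1OCc1ccc(CN2CCCC[C@@H]2C(=O)O)cc1`: 42000 nM
- compound 2 `COc1ccc(/C=C\c2cc(OC)c(OC)c(OC)c2)cc1OCc1ccc(CO)cc1`: 37000 nM

For the measured compounds named here, only these two compounds have values so far, and they cannot be separated. Compound 2, at 37000 nM, lies within the scatter of compound 1, so neither can be ranked on these numbers.

The next compound is compound 3 `COc1ccc(/C=C\c2cc(OC)c(OC)c(OC)c2)cc1OCc1ccc(CNCCNC(C)=O)cc1`, which carries (2-acetamidoethyl)amino in place of hydroxy on a saturated chain carbon bound to an aromatic carbon.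

Going by the values given here, one measured step bears on this change, since it involves the same place on the shared core: a 1.1-fold lower number from compound 1 to compound 2 (0.06 log units; within the scatter). There, hydroxy took the place of 2-carboxypiperidin-1-yl, and the number stayed within the scatter. Among the compounds with values here, this single step is the only guide, and no measured compound carries (2-acetamidoethyl)amino, so the expectation is weakly supported.

No shift beyond the scatter is expected in this assay, and the estimated step is a 1.1-fold lower number from compound 2 to compound 3 (0.02 log units; within the scatter). The range is kept broad in either direction to allow for the untested group.

For compound 3 the estimated value is 35000 nM, with an expected range from 15000 nM to 70000 nM.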

Compound 3, half-maximal inhibitory concentration: > 50000 nM
Compound 3 gave a limit, no number; the forecaster's own chance of this, stated with the estimate: 15%; middle value at least 1.4-fold (0.15 log units) from the limit.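

In this assay compound 3 gives > 50000 nM, which is a limit of the assay and not a number. Going by these compounds, the steps built on it are floors only, an at least 1.3-fold higher number from compound 2 to compound 3 (0.13 log units; that floor lies within the scatter) and an at least 1.1-fold higher number from compound 1 to compound 3 (0.07 log units; that floor lies within the scatter), so the limit does not separate compound 3 from either earlier compound, and its true distance from them remains unknown. What is new is that a third group on the saturated chain carbon bound to an aromatic carbon, here the open-chain (2-acetamidoethyl)amino, still gives no reading beyond the scatter, and that this compound alone of the three has no numerical value: the limit of > 50000 nM in this assay, at which 1 of the 3 values shown sits.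

Still open, on these data alone, is how far compound 3 lies past its limit, and so whether any of the three groups truly differs from the others at this place. A simple primary amine or a longer chain ending in a carboxylic acid on the same carbon could show whether this place moves the number beyond the scatter, and a numerical reading for the (2-acetamidoethyl)amino compound would turn the floors into real steps.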